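Succinimide propanamide piperazines: aryl group change

A few compounds are considered here, and "the series" means these few. Any claim that something is new, unique, unknown or untested is made for them only; others in the source may bear on it.

Measured so far:
compound 1 `COc1cccc(N2CCN(C(=O)C(C)N3C(=O)CCC3=O)CC2)c1` — 0%
compound 2 `CC(C(=O)N1CCN(c2ccc(Cl)cc2)CC1)N1C(=O)CCC1=O` — 25%
compound 3 `CC(C(=O)N1CCN(c2ccc(F)cc2)CC1)N1C(=O)CCC1=O` — 0%

In a functional assay on the whole organism (strain Swiss) with Mus musculus as the target, in the maximal electroshock model, with a stated time of 0.5 h, at a dose of 100 mg/kg by the intraperitoneal route (a lower number here means a weaker effect, a higher number a stronger effect of the compound at the dose given), compound 1 gives 0% and stands level with compound 3, which gives 0%; the two share the bottom of the three numbers. Compound 2 lies above both: a number 25 percentage points higher from compound 1 to compound 2 (beyond the scatter), and a number 25 percentage points lower from compound 2 to compound 3 (beyond the scatter). The third step, no change at the digits printed from compound 1 to compound 3 (within the scatter), shows that exchanging the methoxy-bearing aryl for one halogenated aryl moves nothing, while exchanging it for the other moves a modest amount.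

Compound 4 `CC(C(=O)N1CCN(c2cccc(C(F)(F)F)c2)CC1)N1C(=O)CCC1=O` differs from compound 1 in one place: trifluoromethyl in place of methoxy on an aromatic carbon. Among the measured compounds shown here, none of the measured steps replaces the methoxy by trifluoromethyl, so no step bears on it directly. For the measured compounds named here, the only steps at the aryl group are those from compound 1 to compound 2 and to compound 3, one modest, one within the scatter; the change into compound 4 keeps the group meta to the large group, as in compound 1. A step of at most modest size, upward if any, is therefore expected in this assay.

The estimate for compound 4 is 10%, with a range from 0% to 40%, which means an expected step of a number 10 percentage points higher from compound 1 to compound 4 (within the scatter).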

Compound 4, a percentage reported as activity, at one dose (the size of the read-out at that dose, not a potency): 75%
Compound 4: middle estimate off by 65 percentage points, on the low side, and the stated range ends below it.
By their numbers in this assay, from the lowest: compounds 1 and 3 (each within the scatter of the next); then compound 2; then compound 4.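

In this assay, among the compounds shown here, the aryl group carries far more of the read-out than the earlier compounds indicated: trifluoromethyl in place of methoxy, on an aromatic carbon meta to a large group, gives a number 75 percentage points higher from compound 1 to compound 4 (beyond the scatter). This is a large step, whereas exchanging the whole substituted aryl group gave only a number 25 percentage points higher from compound 1 to compound 2 (beyond the scatter) and no change at the digits printed from compound 1 to compound 3 (within the scatter), so the low number of compound 1 does not mark this position as unresponsive, and a change of one group at an unchanged place on the ring is enough to produce the largest step in the series. The data shown offer no measurement that accounts for this step, so its origin remains unassigned.

The compounds shown leave open whether the step belongs to trifluoromethyl specifically or would also appear with another group at the same place, such as a chloro, a nitrile or a carboxylic acid, and whether trifluoromethyl would give a similar number at another place on the ring. From the compounds shown here alone, it also remains open how the step in this assay would look at other doses or times, since this read-out comes from one dose and is not a potency.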